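A few compounds are considered here, and "the series" means these few. Any claim that something is new, unique, unknown or untested is made for them only; others in the source may bear on it.

Compounds measured so far in an assay on cell membranes with metabotropic glutamate receptor 5 (Rattus norvegicus) as the target; on this read-out lower numbers stand for stronger inhibition and higher numbers for weaker inhibition:

Compound 1 `Cc1nc(C#Cc2cncc(-c3ccccc3)c2)cs1` — 40 nM
Compound 2 `Cc1nc(C#Cc2cncc(-c3cccnc3)c2)cs1` — 1 nM

Compound 2 gives the lowest of the two numbers recorded in this assay; its nearest neighbour is compound 1, and the step of a 40-fold lower number from compound 1 to compound 2 (1.60 log units; beyond the scatter) came with pyridin-3-yl in place of phenyl on an aromatic carbon, a change far beyond the scatter. Compound 3 `Cc1nc(C#Cc2cncc(-c3ccncc3)c2)cs1` has not yet been measured. It differs from compound 2 only in the position of the ring nitrogen: pyridin-4-yl in place of pyridin-3-yl on an aromatic carbon. Among the compounds with values here, the one step on record bears on this change only loosely: it shows that introducing a ring nitrogen into this six-membered ring moved the number a great deal, but it says nothing about where within that ring the nitrogen does its work. With no second pyridinyl isomer measured, the direction of the step from compound 2 to compound 3 cannot be read from the data. A modest weakening is estimated for compound 3, amounting to a 3.0-fold higher number from compound 2 to compound 3 (0.48 log units; beyond the scatter), and its value in this assay is expected to be about 3 nM, within a range from 0.7 nM to 20 nM.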

Compound 3, inhibition constant in the metabotropic glutamate receptor 5 assay: 15 nM
Estimate against measurement, compound 3: 5.0-fold (0.70 log units) below; the measured number falls inside the stated range.
By their numbers in the metabotropic glutamate receptor 5 assay, from the lowest: compound 2; then compound 3; then compound 1.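

In the metabotropic glutamate receptor 5 assay, compound 2 gives 1 nM and compound 3 gives 15 nM. In the metabotropic glutamate receptor 5 assay, moving the ring nitrogen alone, with the same atoms on the same aromatic carbon of the shared core, gives a 15-fold higher number from compound 2 to compound 3 (1.18 log units; beyond the scatter), so where the nitrogen sits within this ring matters and not only that it is there. Set against phenyl, pyridin-4-yl gives a 2.7-fold lower number from compound 1 to compound 3 (0.43 log units; beyond the scatter), which is far smaller than a 40-fold lower number from compound 1 to compound 2 (1.60 log units; beyond the scatter), so both pyridinyl isomers give lower numbers than phenyl, but most of the gain is tied to pyridin-3-yl. In a physicochemical assay for lipophilicity (on this read-out higher numbers stand for higher lipophilicity and lower numbers for lower lipophilicity), compound 2 gives 2.4 and compound 3 gives 2.6. In the physicochemical assay, the same exchange gives a number 0.20 log units higher from compound 2 to compound 3 (within the scatter), so the large step in receptor binding comes with no measurable separation of the two isomers in the physicochemical assay.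

No evidence is at hand on why the place of the ring nitrogen counts for so much at this position. Also open is how pyridin-2-yl, the remaining isomer, or pyrimidin-5-yl, with a second ring nitrogen, would stand on the same core, and whether the order among these three compounds would hold on a different core.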